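Amide-nitrogen substituents on a pyrazole carboxamide series

The compounds below may be only part of what the source reports. "The series", "measured", "known", "first", "only" and "open" are said of these compounds alone.

Working notes on three measured compounds and one open position. In an ADME assay on MRC5 cells (Homo sapiens) for inhibition, with a stated time of 72 h (a higher number here means that more compound is needed for the effect, a lower number that less compound is needed), compound 1 `COc1cccc(OC)c1C(=O)Nc1c[nH]nc1C(=O)NC1CCN(Cc2ccccc2)C1` gives 38000 nM. Compound 2 `COc1cccc(OC)c1C(=O)Nc1c[nH]nc1C(=O)NC1CC1` reaches only the assay limit in this assay, > 50000 nM, so for compound 2 no number is known, only (the limit of > 50000 nM in this assay, at which 1 of the 3 values shown sits). Among the measured compounds shown here, compound 3 `CO[C@H]1CC[C@H](NC(=O)c2n[nH]cc2NC(=O)c2ccccc2C(F)(F)F)CC1`, which carries a different aryl amide and a methoxycyclohexyl on the amide-type nitrogen, gives 3300 nM, a lower value than compound 1, though compound 3 differs from compound 1 in two places at once and no single step between them is measured.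

Compound 4 `CCCCCNC(=O)c1n[nH]cc1NC(=O)c1c(OC)cccc1OC` is not yet measured. It is related to compound 2 by one change: pentyl in place of cyclopropyl on an amide-type nitrogen. For the measured compounds named here, since compound 2 stands at the limit, no measured step is available for this change; what can be said is that the two other measured compounds, both with a larger group on the amide-type nitrogen than cyclopropyl, return numbers rather than limits. On that basis a step from the limit towards a measurable value is expected for compound 4, so that in this assay compound 4 is estimated at 30000 nM (range 9000 nM to 50000 nM), and the expected step is an at least 1.6-fold lower number from compound 2 to compound 4 (0.22 log units; that floor lies within the scatter). A limit read-out for compound 4 remains a real possibility.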

Compound 4, half-maximal effective concentration: > 50000 nM
Compound 4: no number, only a limit; the forecaster's own chance of this, stated with the estimate: 40%; middle value at least 1.6-fold (0.22 log units) away from the limit.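

In this assay compound 2 and compound 4 both stand at a limit rather than a number, so no step between them can be read: the limit of > 50000 nM in this assay, at which 2 of the 4 values shown sit.

The compounds shown leave open whether pentyl in place of cyclopropyl on an amide-type nitrogen changes the read-out at all, as neither group is shown on a compound that returns a number.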